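This account rests on a few compounds, and the source may have more. Where it says the series, first, only, none or still open, it means among the compounds named here.

Of the compounds shown here, two sharing one core have been measured so far in a functional assay on HT-29 cells (Homo sapiens) for antiproliferative activity, read by MTT assay, with a stated time of 72 h (on this read-out lower numbers stand for stronger inhibition and higher numbers for weaker inhibition), on this question. Compound 1 `CNc1nc(-c2cc(OC)c(OC)c(OC)c2)c(-c2ccc(OC)cc2)s1` gives 6.3 nM in this test, and compound 2 `CCOc1ccc(-c2sc(NC)nc2-c2cc(OC)c(OC)c(OC)c2)cc1` gives 3.2 nM in the same test, so compound 2 stands level with compound 1 within the scatter. Within the data shown here, the only measured step is a 2.0-fold lower number from compound 1 to compound 2 (0.29 log units; within the scatter) for methyl in place of hydrogen on a saturated chain carbon bound to an oxygen on an aromatic ring. That step lies elsewhere on the structure and gives only indirect guidance. Compound 3 `CCOc1ccc(-c2sc(N(C)C)nc2-c2cc(OC)c(OC)c(OC)c2)cc1` differs from compound 2 by methyl in place of hydrogen on a nitrogen on an aromatic ring, counted as methyl in place of hydrogen on a nitrogen on an aromatic ring in full, which turns methylamino to dimethylamino. Among the measured compounds shown here, no measured step touches this nitrogen, so the direction rests on judgement of the structural change alone and the margins stay wide. The expected change is a 6.3-fold higher number from compound 2 to compound 3 (0.80 log units; beyond the scatter) in this assay toward weaker inhibition. For compound 3 the estimated value is 20 nM with an expected range of 4 nM to 150 nM in this test.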

Compound 3, half-maximal inhibitory concentration: 6030 nM
The estimate for compound 3 lay 300-fold (2.48 log units) below the measured number, and the stated range ends below it.
By their numbers in this assay, from the lowest: compounds 2 and 1 (each within the scatter of the next); then compound 3.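

In this assay the change of methylamino to dimethylamino gives a 1900-fold higher number from compound 2 to compound 3 (3.28 log units; beyond the scatter), which shows that this nitrogen on an aromatic ring, whose other neighbours are an aromatic carbon and a saturated chain carbon, is highly sensitive to the exchange of one hydrogen for one methyl. Among these compounds, the only earlier step, a 2.0-fold lower number from compound 1 to compound 2 (0.29 log units; within the scatter), made the same kind of exchange on a saturated chain carbon bound to an oxygen on an aromatic ring, so the same small exchange has very different consequences at the two places. Nothing shown here offers an explanation for the size of this loss.

With only methylamino and dimethylamino at this nitrogen, the compounds leave open whether the loss follows from the departure of the hydrogen or from the arrival of the second methyl. From the compounds shown here alone, a free amino group or an ethylamino group at the same place would help separate the two readings, and the effect of dimethylamino alongside the methoxy group of compound 1 also remains open.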